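The compounds below may be only part of what the source reports. "The series", "measured", "known", "first", "only" and "open" are said of these compounds alone.

In a functional assay on PC-3 cells (Homo sapiens) for inhibition, read by sulforhodamine B assay, with a stated time of 48 h (on this read-out lower numbers stand for stronger inhibition of growth and higher numbers for weaker inhibition of growth), three compounds sharing one core have been measured so far. Compound 1 `COc1ccc(/C=C/C2(C)C=CC(=O)O2)c(OC)c1OC` gives 90000 nM. Compound 2 `COc1c(O)ccc(/C=C/C2(C)C=CC(=O)O2)c1OC` gives 131000 nM. Compound 3 `CC1(/C=C/c2cccc(O)c2)C=CC(=O)O1` gives 98800 nM; its nearest neighbour in value is compound 1 and its furthest is compound 2, and both of those gaps are within the usual scatter, so the three compounds cannot be ranked against one another on this read-out. The difference between the core of compound 3 and the core of compound 2 is not broken down here.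

Compound 1 differs from compound 2 by one change, (methyl in place of hydrogen on an oxygen on an aromatic ring), and that change gave a 1.5-fold lower number from compound 2 to compound 1 (0.16 log units; within the scatter), a step that lies within the scatter. Compound 4 `COc1cccc(/C=C/C2(C)C=CC(=O)O2)c1` has not yet been measured in this assay. Within the data shown here, it differs from compound 3 by methyl in place of hydrogen on an oxygen on an aromatic ring, the same change as the one from compound 2 to compound 1, made at a place described in the same words.

Among the measured compounds shown here, with only one earlier instance of this change to draw on, the expectation is modest: the step from compound 3 to compound 4 in this assay is expected to be about a 1.3-fold lower number from compound 3 to compound 4 (0.12 log units; within the scatter), because the same change gave a 1.5-fold lower number from compound 2 to compound 1 (0.16 log units; within the scatter). On that basis compound 4 is expected to give roughly 75000 nM in this assay. The plausible range for compound 4 is estimated to run from 35000 nM to 160000 nM, reflecting that the earlier step itself sat within the scatter.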

Compound 4, concentration for total growth inhibition: 31600 nM
Compound 4: middle estimate off by 2.4-fold (0.38 log units), on the high side; the whole stated range lies above it.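

In this assay, the change from hydroxy to methoxy on an oxygen on an aromatic ring gave a 3.1-fold lower number from compound 3 to compound 4 (0.50 log units; beyond the scatter) and so, on this second core, it produced a step that stands clear of the usual scatter. Set beside the only earlier instance of the same change, this step cannot be told apart from it, since the gap between the two remains within what repeated measurements would allow: the same change on two cores in this assay, a 1.5-fold lower number (0.16 log units; within the scatter) from compound 2 to compound 1 and a 3.1-fold lower number (0.50 log units; beyond the scatter) from compound 3 to compound 4, 2.1-fold (0.33 log units) apart, within the scatter of two such steps. This shows that the size of the step is compatible with carrying over from one core to the other, but it does not show that the two cores respond alike, nor that the core has no influence, as only two instances are available and only one of them lies beyond the scatter.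

On these data alone, the aromatic oxygen in these compounds carries only hydrogen or methyl, so it remains open how a longer chain such as ethyl on that oxygen, or an amine or a carboxylic acid in place of the hydroxy group, would read in this assay. As far as these compounds go, it also remains open whether the step would hold on further cores or in other cell lines.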